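Swapping the Triazole Substituent on an Inactive Chromene Series

The source may report more compounds than this note shows. Statements on the series, on what has been measured and on what is new or still open speak of the compounds shown alone.

Compound 1 `CCOC(=O)C1=Cc2ccccc2OC1(OCc1cc(-c2ccc(C)cc2)no1)C(F)(F)F`, compound 2 `CCOC(=O)C1=Cc2ccccc2OC1(OCc1cn(CC(=O)Nc2ccccc2Br)nn1)C(F)(F)F` and compound 3 `O=C(O)C1=Cc2ccccc2OC1(OCc1cc(-c2ccc([N+](=O)[O-])cc2)no1)C(F)(F)F` share one core and were tested in a functional assay on A549 cells (Homo sapiens) for inhibition, read by MTT assay, with a stated time of 24 h; on this read-out lower numbers stand for stronger inhibition and higher numbers for weaker inhibition. Compound 1 reaches only a limit of this assay, > 150000 nM. Compound 2 likewise returns only a limit, > 150000 nM. Compound 3 too gives nothing but a limit, > 150000 nM. So compound 2 stands at the limit of > 150000 nM in this assay, at which 3 of the 3 values shown sit, and no measured number sets it apart from the other two. Compound 4 `CCOC(=O)C1=Cc2ccccc2OC1(OCc1cn(-c2ccc(C)cc2)nn1)C(F)(F)F` is not yet measured; it differs from compound 2 in one place: 4-methylphenyl in place of ((2-bromophenyl)carbamoyl)methyl on an aromatic nitrogen. Within the data shown here, no pair of measured compounds shows what such a change does in this assay, and because every value shown sits at the limit of > 150000 nM in this assay, at which 3 of the 3 values shown sit, no direction can be read from the data. The step that the limit leaves unreadable from compound 2 to compound 4 in this assay is therefore expected to be none beyond the scatter. Compound 4 is estimated at 200000 nM, between 80000 nM and 500000 nM, most likely reported once more only as a limit.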

Compound 4, half-maximal inhibitory concentration: 19700 nM
Estimate against measurement, compound 4: 10-fold (1.01 log units) above; measured number outside the range, below it.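

Putting 4-methylphenyl in place of ((2-bromophenyl)carbamoyl)methyl on an aromatic nitrogen gives, in this assay, an at least 7.6-fold lower number from compound 2 to compound 4 (0.88 log units; beyond the scatter). Among these compounds, this shows that the group at this position can bring the series within the measurable range, which the earlier compounds did not show. Among the compounds shown here, compound 4, at 19700 nM, is the only compound here with a measured number. The full size of the step stays unknown because its starting point is only a limit: the limit of > 150000 nM in this assay, at which 3 of the 4 values shown sit.

The change replaces the whole group at once, and the compounds shown cannot tell whether the loss of the bromine, of the amide hydrogen or of the chain matters most. From the compounds shown here alone, whether an amine in place of the methyl on the phenyl ring, or a longer chain between that ring and the aromatic nitrogen, would lower the number further also stays open.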